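A few compounds are considered here, and "the series" means these few. Any claim that something is new, unique, unknown or untested is made for them only; others in the source may bear on it.

Among the compounds with values here, the compounds share one core, and two of them carry numbers so far. Compound 1 `COc1ccc(C(=O)Nc2ccc(C)c(Nc3nccc(-c4cccnc4)n3)c2)c(OCCCCn2ccnc2)c1` stands at the lower of the two: in a functional assay on K562 cells (Homo sapiens) for cytotoxicity, read by XTT assay, with a stated time of 24 h (on this read-out lower numbers stand for stronger inhibition and higher numbers for weaker inhibition), compound 1 gives 58900 nM. Compound 2 `Cc1ccc(NC(=O)c2cccc(OCCCCn3ccnc3)c2)cc1Nc1nccc(-c2cccnc2)n1` gives in this assay a value of 74600 nM. These two values lie within the scatter of each other, so no order between compound 1 and compound 2 can be read from them; both sit in the region of weak inhibition.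

Compound 3 `Cc1ccc(NC(=O)c2ccccc2OCCCCn2ccnc2)cc1Nc1nccc(-c2cccnc2)n1` has not yet been measured. Against compound 1 the change is hydrogen in place of methoxy on an aromatic carbon. Nothing else in the series records a step of this kind, so the expectation rests on the two values alone. With both measured compounds close together at weak inhibition, removal of the methoxy is not expected to move the number beyond the scatter in either direction, and any drift is as likely upward as downward.

Compound 3 is therefore estimated in this assay at 65000 nM, with a range from 25000 nM to 170000 nM. The expected step of a 1.1-fold higher number from compound 1 to compound 3 (0.04 log units; within the scatter) is one that should stay within the scatter.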

Compound 3, half-maximal inhibitory concentration: 47500 nM
The estimate for compound 3 lay 1.4-fold (0.14 log units) above the measured number; the measured number falls inside the stated range.
By their numbers in this assay, from the lowest: compounds 3, 1 and 2 (each within the scatter of the next).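

In this assay, hydrogen in place of methoxy on this aromatic carbon, meta to the 4-(1H-imidazol-1-yl)butoxy group and para to a large group, gives a 1.2-fold lower number from compound 1 to compound 3 (0.09 log units; within the scatter) and thus no readable change. Within the data shown here, this is the first step at this position, and it shows that the methoxy, with its 2 heavy atoms and 1 hydrogen-bond acceptor, can leave without a difference that this read-out separates, with compound 1 and compound 3 both remaining in the region of weak inhibition. No measurement at hand accounts for the size of this step.

From the compounds shown here alone, whether a different group on this carbon, such as an amine, a carboxylic acid or an ethoxy, would move the number beyond the scatter remains open, since hydrogen and methoxy are the only two substituents compared here. Also open, going by these compounds, is whether a longer chain, such as a pentyloxy linker to the imidazole in place of the butoxy, would shift the series out of the region of weak inhibition.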